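Chloro to bromo swap across two cores

The compounds below may be only part of what the source reports. "The series", "measured", "known", "first", "only" and "open" are said of these compounds alone.

Measured compounds:
compound 1 `Cn1cc(C2CC(c3ccc(Cl)cc3)=NN2C(=O)c2cccnc2)c2cc(Br)ccc21` gives 8100 nM
compound 2 `Cn1cc(C2CC(c3ccc(Br)cc3)=NN2C(=O)c2cccnc2)c2cc(Br)ccc21` gives 11800 nM
compound 3 `COc1ccc2c(c1)c(C1CC(c3ccc(Cl)cc3)=NN1C(=O)c1ccc(OC)nc1)cn2C` gives 3710 nM

All three were run in a functional assay on MCF7 cells (Homo sapiens) for inhibition, read by MTT assay, with a stated time of 48 h; a lower number here means a stronger inhibitor of growth, a higher number a weaker inhibitor of growth. Compound 1 and compound 2 share one core, and compound 3 carries a second core; the difference between the two cores is not broken down here. Within the first pair the change is bromo in place of chloro on an aromatic carbon and it gave a 1.5-fold higher number from compound 1 to compound 2 (0.16 log units; within the scatter). Compound 4 `COc1ccc2c(c1)c(C1CC(c3ccc(Br)cc3)=NN1C(=O)c1ccc(OC)nc1)cn2C` is unmeasured; it differs from compound 3 by bromo in place of chloro on an aromatic carbon, the same change made at the same place. Among the measured numbers compound 3 stands lowest in this assay. Because the earlier step of a 1.5-fold higher number from compound 1 to compound 2 (0.16 log units; within the scatter) stayed within the scatter, compound 4 is expected to sit close to compound 3, with an expected step of a 1.3-fold higher number from compound 3 to compound 4 (0.13 log units; within the scatter). The estimate for compound 4 in this assay is 5000 nM, expected to lie between 2500 nM and 10000 nM.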

Compound 4, concentration for 50% growth inhibition: 6960 nM
Estimate against measurement, compound 4: 1.4-fold (0.14 log units) below; low and high end bracket the measured number.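

In this assay the swap from 4-chlorophenyl to 4-bromophenyl on the core of compound 3 gives a step (a 1.9-fold higher number from compound 3 to compound 4 (0.27 log units; within the scatter)) that stays within the scatter. Set beside the step on the first core, the two results cannot be told apart: the same change on two cores in this assay, a 1.5-fold higher number (0.16 log units; within the scatter) from compound 1 to compound 2 and a 1.9-fold higher number (0.27 log units; within the scatter) from compound 3 to compound 4, 1.3-fold (0.11 log units) apart, within the scatter of two such steps. This shows that the change carried across these two cores in this one assay without a separable difference, but it does not show that it would carry to any other core or read-out.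

Still open, as far as these compounds go, is how an amine or a carboxylic acid would read at the same place on the phenyl ring. How the differences between the two cores divide up also remains unresolved.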